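A few compounds are considered here, and "the series" means these few. Any claim that something is new, unique, unknown or untested is made for them only; others in the source may bear on it.

Three compounds sharing one core, and differing in one aromatic substituent, have been measured in an ADME assay (liver) for metabolic stability, with Liver microsome (Rattus norvegicus) as the target, using microsomes and NADPH, with a stated time of 30 min, tested at 1 uM; on this read-out higher numbers stand for fast clearance and lower numbers for slow clearance. There, compound 1 `Cn1cc(-c2cc(C(O)(C(F)(F)F)C(F)(F)F)cnc2N2CCN(S(=O)(=O)c3ccc(N)nc3)CC2)cn1` gives 44 mL.min-1.g-1, compound 2 `Nc1ccc(S(=O)(=O)N2CCN(c3ncc(C(O)(C(F)(F)F)C(F)(F)F)cc3-c3ccccc3O)CC2)cn1` gives 125 mL.min-1.g-1 and compound 3 `Nc1ccc(S(=O)(=O)N2CCN(c3ncc(C(O)(C(F)(F)F)C(F)(F)F)cc3-c3cccnc3)CC2)cn1` gives 20 mL.min-1.g-1. Compound 3 therefore holds the lowest number of the three, and its gaps to both others lie beyond the usual scatter.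

Compound 4 `Nc1ccc(S(=O)(=O)N2CCN(c3ncc(C(O)(C(F)(F)F)C(F)(F)F)cc3-c3ccc4scnc4c3)CC2)cn1` keeps the core and alters only that substituent: 1,3-benzothiazol-5-yl in place of pyridin-3-yl on an aromatic carbon. Here 1,3-benzothiazol-5-yl takes the place of pyridin-3-yl on an aromatic carbon, ortho to a large group.

Among the compounds with values here, three measured steps concern this same place, though none includes 1,3-benzothiazol-5-yl. Exchanging the substituent gave a 2.8-fold higher number from compound 1 to compound 2 (0.45 log units; beyond the scatter), then a 2.2-fold lower number from compound 1 to compound 3 (0.34 log units; beyond the scatter) and a 6.3-fold lower number from compound 2 to compound 3 (0.80 log units; beyond the scatter). Each of these is modest, yet beyond the scatter. Neither of the other two substituents reads as low as pyridin-3-yl, so with compound 3 at 20 mL.min-1.g-1, a modest rise is expected in this assay, of a size within the span of the last two steps. The expected change is a 2.5-fold higher number from compound 3 to compound 4 (0.40 log units; beyond the scatter). The estimated value for compound 4 is 50 mL.min-1.g-1, with an expected range of 20 mL.min-1.g-1 to 125 mL.min-1.g-1.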

Compound 4, intrinsic clearance in microsomes: 147 mL.min-1.g-1
Beside the measured number, compound 4's estimate is 2.9-fold (0.47 log units) below it, and the stated range ends below it.
By their numbers in this assay, from the lowest: compound 3; then compound 1; then compounds 2 and 4 (each within the scatter of the next).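

The change to 1,3-benzothiazol-5-yl, with one five-membered and one six-membered aromatic ring, gives a 7.4-fold higher number from compound 3 to compound 4 (0.87 log units; beyond the scatter) in this assay, and it also gives a 3.3-fold higher number from compound 1 to compound 4 (0.52 log units; beyond the scatter), so this place on the ring can carry a much faster clearance than the two lower compounds suggested. High numbers here are also no longer confined to the 2-hydroxyphenyl group: a substituent with no hydroxyl shows a 1.2-fold higher number from compound 2 to compound 4 (0.07 log units; within the scatter), so compound 2 and compound 4 cannot be told apart on this read-out, although the two groups differ in their atoms and ring make-up. Nothing among the data offered explains why either substituent reads so much higher than pyridin-3-yl.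

The compounds shown leave open whether the second fused ring, the sulfur or the loss of the pyridin-3-yl nitrogen goes with the rise, and a plain phenyl group or a quinolin-3-yl group at this place would help to separate these. They also leave open how a pyridin-3-yl group carrying a small amine or a methoxy group would read in the same assay.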